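The source may hold more compounds than are shown below. What is called first, only, known or untested is meant among the compounds shown, and "the series" means these compounds.

Measured in a functional assay on HeLa cells (Homo sapiens) for cytotoxicity, read by MTT assay, with a stated time of 24 h; a higher number here means a weaker inhibitor, a lower number a stronger inhibitor:
- compound 1 `CN1C/C(=C\c2ccc(C#N)cc2)C(=O)/C(=C/c2ccccc2F)C1`: 1340 nM
- compound 2 `CN1C/C(=C\c2ccc(F)cc2)C(=O)/C(=C/c2ccc(C#N)cc2)C1`: 10200 nM

Of these two compounds, compound 2 has the higher number, 10200 nM, which makes it the weaker inhibitor of the pair in this assay. The next compound, compound 3 `CN1C/C(=C\c2ccc(Cl)cc2)C(=O)/C(=C/c2ccc(C#N)cc2)C1`, departs from compound 2 by a single change: chloro in place of fluoro on an aromatic carbon. This puts chloro in place of fluoro on an aromatic carbon, para to a large group.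

For the measured compounds named here, only one measured step bears on this change, and only indirectly: a 7.6-fold higher number from compound 1 to compound 2 (0.88 log units; beyond the scatter). That step was modest but beyond the scatter, and it came with 4-fluorophenyl in place of 2-fluorophenyl. It exchanged one fluorophenyl for another, not one halogen for another, so it does not set the size of the present change. Going by the values given here, no measured pair compares fluoro with chloro directly. No step beyond the scatter is therefore expected in this assay, and no direction is firmly expected either.

For compound 3 the estimated value is 8500 nM, with an expected range from 3500 nM to 20000 nM. The expected step is a 1.2-fold lower number from compound 2 to compound 3 (0.08 log units; within the scatter).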

Compound 3, half-maximal inhibitory concentration: 11200 nM
For compound 3 the middle estimate is 1.3-fold (0.12 log units) below the measured one, within the range that was stated.
By their numbers in this assay, from the lowest: compound 1; then compounds 2 and 3 (each within the scatter of the next).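

In this assay, for the compounds shown here, the exchange from 4-fluorophenyl to 4-chlorophenyl gives a 1.1-fold higher number from compound 2 to compound 3 (0.04 log units; within the scatter) and so provides the first direct comparison of these two halogens, on an aromatic carbon para to a large group. At this position, with the rest of the molecule held constant, the assay does not separate chloro from fluoro. The gap to compound 1 also persists with either halogen: alongside the earlier 7.6-fold higher number from compound 1 to compound 2 (0.88 log units; beyond the scatter), the new comparison gives an 8.4-fold higher number from compound 1 to compound 3 (0.92 log units; beyond the scatter), so the two 4-halophenyl compounds both differ from the 2-fluorophenyl compound by more than the scatter, and no measurement shown here explains why.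

The compounds shown test only two halogens at this position, so it remains open whether the flat result extends to bromo or to groups of a different kind, such as methoxy, an amine or a carboxylic acid. They also leave open whether chloro and fluoro would remain indistinguishable at the 2-position of the phenyl ring, or with a group other than the nitrile-bearing phenyl on the other side of the shared core.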